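A few compounds are considered here, and "the series" means these few. Any claim that something is new, unique, unknown or untested is made for them only; others in the source may bear on it.

Measured in a functional assay on MCF7 cells (Homo sapiens) for inhibition, with a stated time of 72 h; a lower number here means a stronger inhibitor, a higher number a weaker inhibitor:
- compound 1 `COc1ccccc1-c1ccc(CNc2nc(NC3CCC(N)CC3)nc3c2ncn3C2CCCC2)cc1`: 303 nM
- compound 2 `NC1CCC(Nc2nc(NCc3ccc(-c4ccccc4)nc3)c3ncn(C4CCCC4)c3n2)CC1`: 483 nM
- compound 3 `NC1CCC(Nc2nc(NCc3ccc(-c4cccs4)nc3)c3ncn(C4CCCC4)c3n2)CC1`: 92 nM

Compound 1 at 303 nM lies within the scatter of compound 2, while compound 3 gives a number lower than compound 1, beyond the scatter.

Compound 4 `NC1CCC(Nc2nc(NCc3ccc(-c4ccccc4O)cc3)c3ncn(C4CCCC4)c3n2)CC1` is still to be measured in this assay. It differs from compound 1 by hydrogen in place of methyl on an oxygen on an aromatic ring, 2-methoxyphenyl to 2-hydroxyphenyl (hydrogen in place of methyl on an oxygen on an aromatic ring).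

Among the compounds with values here, no measured step makes this exact change. Within the data shown here, the only step available is a 5.3-fold lower number from compound 2 to compound 3 (0.72 log units; beyond the scatter), with thiophen-2-yl in place of phenyl on an aromatic carbon. It is a modest step of a different kind, so it bears only loosely, showing that a single change in an aromatic group can move the number. No direction can be carried over from it, and no shift beyond the scatter is expected.

The estimate is a 1.2-fold lower number from compound 1 to compound 4 (0.07 log units; within the scatter), an expected step with a wide margin. For compound 4 the expected value is 260 nM, within an estimated range from 90 nM to 750 nM.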

Compound 4, half-maximal inhibitory concentration: 2910 nM
Beside the measured number, compound 4's estimate is 11-fold (1.05 log units) below it, and the stated range ends below it.
By their numbers in this assay, from the lowest: compound 3; then compounds 1 and 2 (each within the scatter of the next); then compound 4.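

In this assay, the step from methoxy to hydroxy on the aromatic ring gives a 9.6-fold higher number from compound 1 to compound 4 (0.98 log units; beyond the scatter), so this oxygen is a place where the loss of a single methyl, with hydrogen entering in its place, moves the number well beyond the scatter. Within the data shown here, until now, the only single-place step was the exchange of a whole aromatic group, thiophen-2-yl for phenyl, and it lowered the number; this smaller change in the 2-methoxyphenyl group raises it. Nothing available accounts for the size of this rise.

The compounds shown leave open how an ethoxy group, an amine or a carboxylic acid at this place would read. They also leave open whether the same change from methoxy to hydroxy would have a similar effect on another compound in the series.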